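This account rests on a few compounds, and the source may have more. Where it says the series, first, only, none or still open, it means among the compounds named here.

Compound 1 `Cc1nnc(SCC(=O)N/N=c2/scc(-c3ccc(F)cc3)n2-c2ccccc2)s1` was tested in a functional assay on C6 cells (Rattus norvegicus) for cytotoxicity, read by MTT assay, with a stated time of 24 h, tested at 200 ug/mL (on this read-out higher numbers stand for a weaker effect at the one concentration tested and lower numbers for a stronger effect), and gives 26.5%. Compound 2 `O=C(CSc1nnnn1-c1ccccc1)N/N=c1/scc(-c2ccc(F)cc2)n1-c1ccccc1` gives 30.6% in this assay, and compound 3 `Cc1ccc(-c2cs/c(=N/NC(=O)CSc3nnnn3C)n2-c2ccccc2)cc1` gives 39.7%. Compound 1 thus sits lower than compound 3 by a margin beyond the scatter, while compound 2 lies within the scatter of it. The unmeasured compound 4 `COc1ccc(-c2cs/c(=N/NC(=O)CSc3nnc(C)s3)n2-c2ccccc2)cc1` differs from compound 1 in one place: methoxy in place of fluoro on an aromatic carbon. Among the compounds with values here, no measured step touches this change. Within the data shown here, the only measured step, a number 4.1 percentage points higher from compound 1 to compound 2 (within the scatter), alters the group on the sulfur instead and lies within the scatter. With nothing to point either way, the expectation is a move within the scatter only, a number 4.5 percentage points higher from compound 1 to compound 4 (within the scatter). Compound 4 is therefore estimated at 31%, ranging from 16% to 50%.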

Compound 4, a percentage reported as activity, at one concentration (the size of the read-out at that concentration, not a potency): 22.2%
Compound 4: the middle estimate sits 8.8 percentage points above what was measured, within the range that was stated.
By their numbers in this assay, from the lowest: compounds 4, 1, 2 and 3 (each within the scatter of the next, the first and the last beyond it).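

In this assay, within the data shown here, methoxy in place of fluoro on an aromatic carbon para to a large group gives a number 4.3 percentage points lower from compound 1 to compound 4 (within the scatter), the first measured step at this position. With 5-methyl-1,3,4-thiadiazol-2-yl on the sulfur, the change from 4-fluorophenyl to 4-methoxyphenyl therefore leaves the read-out within the scatter. No available evidence bears on this outcome.

As far as these compounds go, whether an amine or a carboxylic acid on this aromatic carbon would also stay within the scatter remains open. So does whether the same change behaves alike with the 1-phenyl-1H-tetrazol-5-yl group of compound 2 on the sulfur.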